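A few compounds are considered here, and "the series" means these few. Any claim that something is new, unique, unknown or untested is made for them only; others in the source may bear on it.

Compound 1 `ClCc1cccc(Cn2cnc3c(Cl)nc(Cl)nc32)c1` in a functional assay on SF-268 cells (Homo sapiens) for cytotoxicity, read by sulforhodamine B assay, with a stated time of 48 h; a higher number here means that more compound is tolerated, a lower number that less compound is tolerated: 70800 nM
Compound 2 `ClCc1ccccc1Cn1cnc2c(Cl)nc(Cl)nc21` in this assay: "not determined" (no result reported)

Two compounds have so far entered this assay. For the measured compounds named here, compound 1 stands alone on the numbers: it holds the only reported value, while compound 2 carries no result. Compound 3 `Nc1nc(Cl)c2ncn(Cc3cccc(CCl)c3)c2n1` is still unmeasured. It differs from compound 1 at one place: amino in place of chloro on an aromatic carbon. Going by the values given here, no pair of measured compounds that differ in a single place is available, so nothing in the present data shows how such a change has moved the read-out before. Without such guidance, the step is expected to be small, no larger than the usual scatter, and its direction is left open; the expected size is a 1.1-fold higher number from compound 1 to compound 3 (0.05 log units; within the scatter). Compound 3 is therefore estimated to give about 80000 nM in this assay, with a range from 30000 nM to 200000 nM.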

Compound 3, concentration lethal to 50% of the cells: 67600 nM
For compound 3 the middle estimate is 1.2-fold (0.07 log units) above the measured one; measured number inside the range.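

In this assay, for the compounds shown here, putting amino in place of chloro on the aromatic carbon between two ring nitrogen atoms gives a 1.0-fold lower number from compound 1 to compound 3 (0.02 log units; within the scatter), the first single-place change that can be read. At this position, the two groups therefore give values within the scatter of each other, even though the amino group brings a hydrogen-bond donor and acceptor that the chloro group does not. No measurement shown here explains why the two groups read alike.

From the compounds shown here alone, whether other groups at this carbon, such as a methoxy group or a dimethylamino group, would also stay within the scatter remains open. So does the outcome of the same exchange at the remaining chloro group, and compound 2, with no reported result, gives no reading of the chloromethyl group's placement.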